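The source may report more compounds than this note shows. Statements on the series, on what has been measured and on what is new or still open speak of the compounds shown alone.

For the measured compounds named here, in an ADME assay on CEM-SS cells (Homo sapiens) for cytotoxicity, read by XTT assay, with a stated time of 6 days (a higher number here means that more compound is tolerated, a lower number that less compound is tolerated), compound 2 `CCCC(=O)OCSc1ccccc1C(=O)NCCCCNC(C)=O` gives 17.4 uM, the only single number among the three measured compounds. Compound 3 `CCCC(=O)OCSc1ccccc1C(=O)N[C@H]1CCC[C@@H]1C(N)=O` has repeat entries of 31.2 uM; 43.3 uM (2 entries). Compound 1 `CCCC(=O)OCSc1ccccc1C(=O)NC1(C(N)=O)CCCC1` is reported only as a limit, > 100 uM.

Compound 4 `CCCC(=O)OCSc1ccccc1C(=O)NCC(=O)N(C)C` shares its core with these compounds and has not yet been measured. Its difference from compound 2 is this: dimethylcarbamoyl in place of 3-acetamidopropyl on a saturated chain carbon bound to an amide-type nitrogen. Cut one bond further out, the same change takes 4-acetamidobutyl to (dimethylcarbamoyl)methyl.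

Going by the values given here, only one measured step involves the group that compound 4 gives up. That step is an at least 5.7-fold lower number from compound 1 to compound 2 (0.75 log units; beyond the scatter), in which 4-acetamidobutyl takes the place of 1-carbamoylcyclopentyl. Read in reverse, it suggests that losing 4-acetamidobutyl may raise the number. The evidence is thin, however, since the group entering compound 4 is a different one and the measured step starts from a limit. A modest rise is therefore the fair expectation, not one of the full size seen there. The expected change is a 2.6-fold higher number from compound 2 to compound 4 (0.41 log units; beyond the scatter), towards more compound being tolerated. The estimated value for compound 4 is 45 uM, with an expected range of 18 uM to 100 uM.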

Compound 4, half-maximal toxic concentration: 38.3 uM
The estimate for compound 4 lay 1.2-fold (0.07 log units) above the measured number, and the stated range covers the measured number.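

In this assay, the swap of 3-acetamidopropyl for dimethylcarbamoyl on a saturated chain carbon bound to an amide-type nitrogen gives a 2.2-fold higher number from compound 2 to compound 4 (0.34 log units; beyond the scatter). For the compounds shown here, this is the first measured change that keeps an open chain with no ring on the amide-type nitrogen, so the gain over compound 2 does not depend on a ring in that group. The other new step, an at least 2.6-fold lower number from compound 1 to compound 4 (0.41 log units; beyond the scatter), shows that this open chain still does not reach the level of the cyclopentyl group, and its size can be read only as a minimum because the value of compound 1 is a limit: the limit of > 100 uM in this assay, at which 1 of the 4 values shown sits.

The step from compound 2 to compound 4 changes several things at once, since the entering group is smaller and also differs in hydrogen-bond donors, and the compounds shown cannot tell these apart. A dimethylcarbamoyl group carried on a longer chain, or a plain carboxamide with two hydrogens on its nitrogen in the same place, would help to separate chain length from the change at the end of the chain.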